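A few compounds are considered here, and "the series" means these few. Any claim that something is new, unique, unknown or untested is made for them only; others in the source may bear on it.

Measured so far:
compound 1 `Cc1cccc(NN=C2CCC(C)n3c2ncc(C(=O)O)c3=O)c1C` — > 100 umol/kg
compound 2 `CC1CCC(=NNc2cc(Cl)cc(Cl)c2)c2ncc(C(=O)O)c(=O)n21` — > 100 umol/kg

Two compounds of the series have been run in a functional assay on the whole organism with Rattus norvegicus as the target; on this read-out lower numbers stand for an effect already at smaller amounts and higher numbers for an effect only at larger amounts of compound. Compound 1 `Cc1cccc(NN=C2CCC(C)n3c2ncc(C(=O)O)c3=O)c1C` gives only a limit in this assay, > 100 umol/kg. Compound 2 `CC1CCC(=NNc2cc(Cl)cc(Cl)c2)c2ncc(C(=O)O)c(=O)n21` likewise gives only a limit in this assay, > 100 umol/kg. Going by the values given here, the single step between them, a step that the two limits leave unreadable from compound 1 to compound 2, cannot be read from these two values. Among the compounds with values here, compound 2 thus stands at the limit of this assay, the same place as the only other value shown (the limit of > 100 umol/kg in this assay, at which 2 of the 2 values shown sit).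

The next compound, compound 3 `CC1CCC(=NNc2ccc(Br)cc2Cl)c2ncc(C(=O)O)c(=O)n21`, differs from compound 2 as follows: 4-bromo-2-chlorophenyl in place of 3,5-dichlorophenyl on an amine nitrogen. Within the data shown here, no measured step bears on this change; the only step on record, a step that the two limits leave unreadable from compound 1 to compound 2, is unreadable, since both values sit at the limit (the limit of > 100 umol/kg in this assay, at which 2 of the 2 values shown sit). With every value shown at the limit, neither a direction nor a size of effect can be drawn from the measured compounds for this change. The step from compound 2 to compound 3 is therefore expected to be a step that the limit leaves unreadable from compound 2 to compound 3, meaning no readable shift away from the limit. For compound 3 the expected value in this assay is 150 umol/kg, with a range from 40 umol/kg to 600 umol/kg, and the most likely outcome is expected to be again a limit rather than a number.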

Compound 3, dose for 50% inhibition: > 100 umol/kg
Compound 3: a limit, no number (the forecaster's own chance of this, stated with the estimate: 75%); the middle value does not contradict the limit.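

Compound 3 gives only a limit in this assay, so no step linking it to compound 1 or compound 2 can be read: the limit of > 100 umol/kg in this assay, at which 3 of the 3 values shown sit.

The compounds shown leave open whether any group on the amine nitrogen gives a numerical value in this assay, and how the three substituted phenyl groups compare.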